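The compounds below may be only part of what the source reports. "The series", "measured", "known", "first", "only" and "open" are said of these compounds alone.

Measured in a functional assay on A549 cells (Homo sapiens) for cytotoxicity, with a stated time of 48 h; on this read-out higher numbers stand for weaker inhibition of growth and lower numbers for stronger inhibition of growth:
Compound 1 `Nc1nc(-c2cc(N3C[C@H](O)[C@@H](O)C3)ccc2O)cc(C2CCCNC2)n1`: > 10000 nM, which is a limit of the assay.
Compound 2 `CCc1cc(-c2cc(N3C[C@H](O)[C@@H](O)C3)ccc2O)nc(N)n1`: 3000 nM.

For the measured compounds named here, compound 2, at 3000 nM, holds the only actual number so far in this assay, so there is no wider scale against which to place it. The next compound to be measured is compound 3 `Nc1nc(-c2cc(N3C[C@H](O)[C@@H](O)C3)ccc2O)cc(C2CCCC2)n1`, which carries cyclopentyl in place of ethyl on an aromatic carbon. Going by the values given here, only one measured step concerns this carbon: an at least 3.3-fold lower number from compound 1 to compound 2 (0.52 log units; beyond the scatter). Among the compounds with values here, compound 3 shares with compound 1 a non-aromatic ring at this place, but its ring is of carbon only, and no measured compound carries such a group. A single step cannot show whether the ring itself matters. Within the data shown here, with an at least 3.3-fold lower number from compound 1 to compound 2 (0.52 log units; beyond the scatter) as the only guide, no step beyond the scatter is expected in this assay, and no direction can be firmly expected, although a weaker result remains possible. The estimated step is no change at the digits printed from compound 2 to compound 3 (within the scatter). Compound 3 is expected at 3000 nM, within an estimated range of 800 nM to 10000 nM.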

Compound 3, concentration for 50% growth inhibition: 2000 nM
The estimate for compound 3 lay 1.5-fold (0.18 log units) above the measured number; the measured number falls inside the stated range.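

In this assay, the aromatic carbon next to the ring nitrogen accepts cyclopentyl in place of ethyl with a 1.5-fold lower number from compound 2 to compound 3 (0.18 log units; within the scatter), so compound 2 and compound 3 cannot be told apart, although the group grows from 2 to 5 heavy atoms and gains a ring. A non-aromatic ring at this carbon therefore does not by itself go with the weak result of compound 1, and cyclopentyl in place of piperidin-3-yl gives an at least 5.0-fold lower number from compound 1 to compound 3 (0.69 log units; beyond the scatter), a change that alters both ring size and ring atoms. Compound 1 stands at a limit of the assay, so the full size of the steps from it cannot be read: the limit of > 10000 nM in this assay, at which 1 of the 3 values shown sits.

The compounds shown do not separate the nitrogen of piperidin-3-yl from the larger ring size, a question that cyclohexyl or pyrrolidin-3-yl at this carbon would address. On these data alone, how far this carbon accepts other groups also stays open, for example a longer alkyl chain, an aminomethyl group or a carboxylic acid.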